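The source may hold more compounds than are shown below. What is called first, only, known or untested is meant among the compounds shown, and "the series" means these compounds.

Compound 1 `O=C(O[C@H]1C[C@H](n2cc(F)c(=O)[nH]c2=O)O[C@@H]1COP(=O)(O)Oc1cccnc1)c1ccccc1` is the reference here. In a functional assay on T47D cells (Homo sapiens) for cytotoxicity, read by MTT assay, with a stated time of 48 h (a higher number here means a weaker inhibitor, a lower number a stronger inhibitor), compound 1 gives 14400 nM, the highest of the three numbers recorded. Going by the values given here, compound 2 `O=C(O[C@H]1C[C@H](n2cc(F)c(=O)[nH]c2=O)O[C@@H]1COP(=O)(O)Oc1ccc2ncccc2c1)c1ccccc1` is the closest neighbour of compound 1; in this assay compound 2 gives 7140 nM, and the only single-point step in the set, a 2.0-fold lower number from compound 1 to compound 2 (0.30 log units; within the scatter), stays within the scatter. Among the compounds with values here, compound 3 `O=C(O[C@H]1C[C@H](n2cc(F)c(=O)[nH]c2=O)O[C@@H]1COP(=O)([O-])Oc1ccc[n+](Cc2ccccc2)c1)c1ccccc1` gives 3430 nM; no single-point step links it to compound 1, so its number can only be set beside that of compound 1, where it is the furthest of the three.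

Compound 4 `C[N+]1(C)CCC(OP(=O)([O-])OC[C@H]2O[C@@H](n3cc(F)c(=O)[nH]c3=O)C[C@@H]2OC(=O)c2ccccc2)CC1` has not yet been measured. It departs from compound 1 as follows: a group of 12 heavy atoms (7 carbon, 1 nitrogen, 3 oxygen, 1 phosphorus; one six-membered non-aromatic ring with 1 hetero atom) in place of a group of 10 heavy atoms (5 carbon, 1 nitrogen, 3 oxygen, 1 phosphorus; one six-membered aromatic ring with 1 hetero atom), on an oxygen on a saturated carbon. The one six-membered aromatic ring with 1 hetero atom of the group that leaves gives way to one six-membered non-aromatic ring with 1 hetero atom, and the group that enters has 0 hydrogen-bond donors where the group that leaves has 1. Within the data shown here, only the step from compound 1 to compound 2 bears on a change at this oxygen, and that step was within the scatter; compound 4, however, moves further from compound 1 than compound 2 did, and no measured step covers a non-aromatic ring there. Compound 4 is therefore expected to stay close to compound 1, with any change, a 1.4-fold lower number from compound 1 to compound 4 (0.16 log units; within the scatter), not clearly beyond the scatter. The estimate for compound 4 in this assay is 10000 nM, within a range from 3500 nM to 30000 nM.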

Compound 4, half-maximal inhibitory concentration: 11900 nM
For compound 4 the middle estimate is 1.2-fold (0.08 log units) below the measured one; the range from low to high includes it.
By their numbers in this assay, from the lowest: compound 3; then compounds 2, 4 and 1 (each within the scatter of the next).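

The step of a 1.2-fold lower number from compound 1 to compound 4 (0.08 log units; within the scatter) shows that, in this assay, a six-membered non-aromatic ring with 1 hetero atom can take the place of a six-membered aromatic ring with 1 hetero atom on this oxygen on a saturated carbon without a change beyond the scatter. Going by these compounds alone, until now, the only single-point change read at this oxygen had been one aromatic group for another, so the tolerance now reaches a non-aromatic ring and an entering group with 0 hydrogen-bond donors where the leaving group has 1. No supporting measurement bears on this result, which therefore stands as an observation alone.

On these data alone, what an open-chain group, such as an aminoethyl chain, would give on this oxygen remains open. So does the reading for a plain cyclohexyl ring, with carbon in place of the ring nitrogen.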